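From compound 3 to compound 4: one group exchanged

The compounds below may be only part of what the source reports. "The series", "measured", "known", "first", "only" and "open" are said of these compounds alone.

Measured in a functional assay on COR-L23 cells (Homo sapiens) for antiproliferative activity, read by CellTiter-Glo, with a stated time of 72 h; on this read-out lower numbers stand for stronger inhibition and higher numbers for weaker inhibition:
- compound 1 `C[C@@H](c1ccc(NC(=O)N2CC(c3cccnc3)C2)cc1)N1Cc2ccccc2C1=O`: 8 nM
- compound 2 `C[C@H](NC(=O)c1cccc(F)c1)c1ccc(NC(=O)N2CC(c3cccnc3)C2)cc1`: 10 nM
- compound 3 `C[C@@H](c1ccc(NC(=O)N2CC(c3ccc(N)nc3)C2)cc1)N1Cc2ccccc2C1=O`: 19 nM

Compound 3 gives 19 nM, which lies within the scatter of compound 2 at 10 nM. Its distance from the third measured structure is a 2.4-fold higher number from compound 1 to compound 3 (0.38 log units; beyond the scatter), the result of adding the amino group. Compound 4 `C[C@H](NC(=O)c1cccc(F)c1)c1ccc(NC(=O)N2CC(c3ccc(N)nc3)C2)cc1` is still unmeasured and differs from compound 3 as follows: a group of 10 heavy atoms (7 carbon, 1 nitrogen, 1 oxygen, 1 fluorine; one six-membered aromatic ring of carbon only) in place of a group of 10 heavy atoms (8 carbon, 1 nitrogen, 1 oxygen; one five-membered non-aromatic ring with 1 hetero atom, one six-membered aromatic ring of carbon only), on a saturated chain carbon bound to an aromatic carbon and a saturated chain carbon. Among the compounds with values here, the same exchange, made without the amino group, gave a 1.3-fold higher number from compound 1 to compound 2 (0.10 log units; within the scatter), and this is the closest precedent. No step beyond the scatter is therefore expected in this assay, and the estimated step is a 1.3-fold higher number from compound 3 to compound 4 (0.10 log units; within the scatter). Compound 4 is expected at 24 nM, within an estimated range of 11 nM to 50 nM.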

Compound 4, half-maximal inhibitory concentration: 27 nM
The estimate for compound 4 lay 1.1-fold (0.05 log units) below the measured number, within the range that was stated.
By their numbers in this assay, from the lowest: compounds 1, 2, 3 and 4 (each within the scatter of the next, the first and the last beyond it).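

In this assay, placing ((3-fluorophenyl)carbonyl)amino on the saturated chain carbon gives a 1.4-fold higher number from compound 3 to compound 4 (0.15 log units; within the scatter), so the exchange stays within the scatter with the amino group present as well as without it: the same change on two cores in this assay, a 1.3-fold higher number (0.10 log units; within the scatter) from compound 1 to compound 2 and a 1.4-fold higher number (0.15 log units; within the scatter) from compound 3 to compound 4, 1.1-fold (0.06 log units) apart, within the scatter of two such steps

With ((3-fluorophenyl)carbonyl)amino in place, adding the amino group gives a 2.7-fold higher number from compound 2 to compound 4 (0.43 log units; beyond the scatter), so its modest cost is not confined to the first core: the same change on two cores in this assay, a 2.4-fold higher number (0.38 log units; beyond the scatter) from compound 1 to compound 3 and a 2.7-fold higher number (0.43 log units; beyond the scatter) from compound 2 to compound 4, 1.1-fold (0.06 log units) apart, within the scatter of two such steps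

Across these four compounds, the two changes therefore combine without any visible interaction.

The compounds shown leave open how a carboxylic acid or a longer chain would fare on that saturated chain carbon. They also leave open whether a methoxy or dimethylamino group would match the amino group.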